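The compounds below may be only part of what the source reports. "The series", "measured", "known", "first", "only" and "open" are said of these compounds alone.

Going by the values given here, compound 2 `O=C(Nc1ccc2nccn2c1)N1CCN(Cc2cccc(Oc3ccc(Cl)cc3)c2)CC1` gives 3600 nM in an assay on isolated protein for inhibition of Fatty-acid amide hydrolase 1 (Rattus norvegicus), with a stated time of 60 min (on this read-out lower numbers stand for stronger inhibition and higher numbers for weaker inhibition), the highest of the two numbers so far. Compound 1 `O=C(Nc1cccc2nonc12)N1CCN(Cc2cccc(Oc3ccc(Cl)cc3)c2)CC1` gives 120 nM; the change a 30-fold higher number from compound 1 to compound 2 (1.48 log units; beyond the scatter) exchanged the whole ring system. Compound 3 `O=C(Nc1cccc2nccn12)N1CCN(Cc2cccc(Oc3ccc(Cl)cc3)c2)CC1` keeps the same atoms as compound 2, joined differently: a group of 9 heavy atoms (7 carbon, 2 nitrogen; one five-membered aromatic ring with 2 hetero atoms, one six-membered aromatic ring with 1 hetero atom) in place of a group of 9 heavy atoms (7 carbon, 2 nitrogen; one five-membered aromatic ring with 2 hetero atoms, one six-membered aromatic ring with 1 hetero atom), on an amide-type nitrogen. Among the compounds with values here, no measured step covers such a rearrangement, so the single measured step bears on it only loosely. For compound 3 the expected step is a 3.0-fold lower number from compound 2 to compound 3 (0.48 log units; beyond the scatter), in the stronger direction but uncertain. Compound 3 is estimated at 1200 nM, within 250 nM to 6000 nM.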

Compound 3, half-maximal inhibitory concentration: 5.7 nM
Compound 3: middle estimate off by 210-fold (2.32 log units), on the high side; the whole stated range lies above it.
By their numbers in this assay, from the lowest: compound 3; then compound 1; then compound 2.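

On the amide-type nitrogen, the same atoms joined differently give a 630-fold lower number from compound 2 to compound 3 (2.80 log units; beyond the scatter), so the way the ring system is put together matters here, not only which atoms it holds. This step is larger than the one that exchanged the whole ring system, and compound 3 also passes the earlier lower value, with a 21-fold lower number from compound 1 to compound 3 (1.32 log units; beyond the scatter). No measurement here explains why the two arrangements differ so much. As far as these compounds go, whether a methyl group or a fluorine atom on the ring system of compound 3 would keep this low number remains open.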